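A carboxylic acid series measured for antiproliferative effect

The compounds below may be only part of what the source reports. "The series", "measured", "known", "first", "only" and "open" are said of these compounds alone.

Three compounds sharing one core were measured in a functional assay on BJAB cells (Homo sapiens) for antiproliferative activity, with a stated time of 4 days; a lower number here means that less compound is needed, a higher number that more compound is needed for the effect. Compound 1 `Cc1nn(-c2nc(-c3ccc(Cl)c(Cl)c3)c(SC(C)C)s2)c(C(=O)O)c1-c1cncnc1` gives 22000 nM. Compound 2 `Cc1cc(-c2c(C)nn(-c3nc(-c4ccc(Cl)c(Cl)c4)c(SC(C)C)s3)c2C(=O)O)cc(C)n1` gives 580 nM, and the step of a 38-fold lower number from compound 1 to compound 2 (1.58 log units; beyond the scatter) is the largest seen in the set. Compound 3 `Cc1nn(-c2nc(-c3ccc(Cl)c(Cl)c3)c(SC(C)C)s2)c(C(=O)O)c1Cc1ccccc1[N+](=O)[O-]` gives 20000 nM, the second highest of the three numbers; compound 1 sits nearest, with the step of a 1.1-fold lower number from compound 1 to compound 3 (0.04 log units; within the scatter) lying within the scatter, whereas the step of a 34-fold higher number from compound 2 to compound 3 (1.54 log units; beyond the scatter) is large and sets compound 2 far apart.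

The next step leads to compound 4 `CC(=O)Nc1ccc(-c2c(C)nn(-c3nc(-c4ccc(Cl)c(Cl)c4)c(SC(C)C)s3)c2C(=O)O)cc1`, which differs from compound 3 in one place: 4-acetamidophenyl in place of 2-nitrobenzyl on an aromatic carbon. Among the measured compounds shown here, two measured steps bear on this change. The step of a 34-fold higher number from compound 2 to compound 3 (1.54 log units; beyond the scatter) shows that exchanging a directly bonded six-membered aromatic ring for the 2-nitrobenzyl group costs a great deal, while the step of a 1.1-fold lower number from compound 1 to compound 3 (0.04 log units; within the scatter) shows that not every directly bonded ring is rewarded. Since compound 4 again carries a directly bonded six-membered aromatic ring, a moderate move toward lower numbers is expected, though far short of the gain seen with compound 2. The step from compound 3 to compound 4 is therefore estimated at a 4.0-fold lower number from compound 3 to compound 4 (0.60 log units; beyond the scatter). For compound 4 the expected value in this assay is 5000 nM, within a range from 1000 nM to 25000 nM.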

Compound 4, half-maximal effective concentration: 139000 nM
Beside the measured number, compound 4's estimate is 28-fold (1.44 log units) below it; the measured number lies above the stated range.
By their numbers in this assay, from the lowest: compound 2; then compounds 3 and 1 (each within the scatter of the next); then compound 4.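

This result shows that the position can push the number well above the level of compounds 1 and 3: in this assay compound 4 stands highest of the four, with a 7.0-fold higher number from compound 3 to compound 4 (0.84 log units; beyond the scatter) and a 6.3-fold higher number from compound 1 to compound 4 (0.80 log units; beyond the scatter). It also widens the spread at this one position, as a 240-fold higher number from compound 2 to compound 4 (2.38 log units; beyond the scatter) is the largest step in the set, and 4-acetamidophenyl and 2,6-dimethylpyridin-4-yl both place a six-membered aromatic ring directly on the same aromatic carbon. Among the three compounds with a directly bonded ring, only compound 2 has a low number, so such a ring does not bring a low number by itself, with compounds 1 and 4 going against that idea, and nothing measured here accounts for the difference.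

The compounds shown do not separate the part played by the ring nitrogen of compound 2 from that of its two methyl groups, a question that a phenyl ring carrying two methyl groups would address. They also leave open whether the rise in compound 4 goes with the acetamido group as a whole, which a plain phenyl ring or a phenyl ring carrying an amine in its place would help to settle.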